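The source may hold more compounds than are shown below. What is called first, only, known or untested is meant among the compounds shown, and "the series" means these compounds.

Compound 1 `CNC(=O)c1cc(Oc2ccc3sc(Nc4cccc(C(C)(C)C)c4)nc3c2)ccn1`: 10 10^-6 cm/s
Compound 2 `CNC(=O)c1cc(Oc2ccc3oc(Nc4cccc(C(F)(F)F)c4)nc3c2)ccn1`: 10 10^-6 cm/s

Both were tested in an ADME assay on Caco-2 cells (Homo sapiens) for permeability, in the apical to basolateral direction; a lower number here means that the compound crosses the layer more slowly, a higher number that the compound crosses the layer faster. In this assay compound 2 gives 10 10^-6 cm/s, level with compound 1 at the digits shown, so the two lie within the scatter of the method. Compound 3 `CNC(=O)c1cc(Oc2ccc3oc(Nc4ccc(C(C)C)cc4)nc3c2)ccn1` differs from compound 2 by 4-isopropylphenyl in place of 3-(trifluoromethyl)phenyl on a nitrogen on an aromatic ring. For the measured compounds named here, no measured pair shows what this change does, so the expectation is a step within the scatter, in no clear direction. The expected step is no change at the digits printed from compound 2 to compound 3 (within the scatter). Compound 3 is therefore estimated at 10 10^-6 cm/s, with a range from 5 10^-6 cm/s to 20 10^-6 cm/s.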

Compound 3, apparent permeability: 10 10^-6 cm/s
For compound 3 middle estimate and measured number coincide at the digits printed, and the stated range covers the measured number.
By their numbers in this assay, from the lowest: compounds 1, 2 and 3 (each within the scatter of the next).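

Measured in this assay the exchange of 3-(trifluoromethyl)phenyl for 4-isopropylphenyl on a nitrogen on an aromatic ring gives no change at the digits printed from compound 2 to compound 3 (within the scatter) and is the first step in one place among these compounds. At this position, then, a group made of carbon only and a group carrying fluorine read alike for this pair. The data offer no measurement that would explain this result. Still open, from the compounds shown here alone, is whether a phenyl ring carrying an amine or a carboxylic acid at this position would also read alike in this assay and so extend this picture.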